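Cyano for Bromo on the Fused Ring of Compound 3

The source may hold more compounds than are shown below. What is called first, only, known or untested is meant among the compounds shown, and "the series" means these compounds.

Compound 1, `COc1cc([C@](O)(CCN(C)C)[C@@H](c2cc3cc(Br)ccc3nc2OC)c2cccc(OC)c2F)cc(OC(F)F)n1`: 0.1 uL/min
Compound 2, `COc1cc([C@](O)(CCN(C)C)[C@@H](c2cc3cc(C#N)ccc3nc2OC)c2cccc(OC)c2F)cc(SC)n1`: 16 uL/min
Compound 3, `COc1cccc([C@H](c2cc3cc(Br)ccc3nc2OC)[C@@](O)(CCN(C)C)c2cc(SC)nc(SC)c2)c1F`: 3.4 uL/min

Among the three compounds measured in an ADME assay on microsomes from liver (Homo sapiens) for metabolic stability (a lower number here means slower removal, a higher number faster removal of the compound), compound 3 stands second highest with 3.4 uL/min. Its nearest neighbour is compound 2 at 16 uL/min, its furthest is compound 1 at 0.1 uL/min. Among the compounds with values here, the only single-step comparison available, a 34-fold higher number from compound 1 to compound 3 (1.53 log units; beyond the scatter), concerns the ring bound to the hydroxyl-bearing carbon and not the fused ring.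

Compound 4, `COc1cccc([C@H](c2cc3cc(C#N)ccc3nc2OC)[C@@](O)(CCN(C)C)c2cc(SC)nc(SC)c2)c1F`, differs from compound 3 in cyano in place of bromo on an aromatic carbon. Within the data shown here, no measured pair isolates this change: compound 1 and compound 2 carry it, but they also differ in the other ring, and the value of compound 1, 0.1 uL/min, set against that of compound 2, 16 uL/min, only shows a wide gap for both changes together. Compound 4 is therefore expected to sit near compound 3, with a step of a 1.8-fold higher number from compound 3 to compound 4 (0.25 log units; within the scatter) that may not exceed the scatter, leaning slightly upward. The estimate for compound 4 is 6 uL/min, within 2 uL/min to 18 uL/min.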

Compound 4, intrinsic clearance in a liver preparation (reported as CLH), per the amount of preparation that the assay uses: 15 uL/min
Beside the measured number, compound 4's estimate is 2.5-fold (0.40 log units) below it; measured number inside the range.
By their numbers in this assay, from the lowest: compound 1; then compound 3; then compounds 4 and 2 (each within the scatter of the next).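

In this assay, within the data shown here, the position on the fused ring is now isolated for the first time: cyano in place of bromo on an aromatic carbon gives a 4.4-fold higher number from compound 3 to compound 4 (0.64 log units; beyond the scatter) and so moves the number by itself, with no change elsewhere in the molecule. With cyano held at that position, methylsulfanyl in place of methoxy on an aromatic carbon gives a 1.1-fold lower number from compound 2 to compound 4 (0.03 log units; within the scatter) and so does not separate these two compounds. Nothing available explains either result.

From the compounds shown here alone, whether cyano in place of bromo gives a step of similar size on the core of compound 1, whose value of 0.1 uL/min lies far from the others, remains open. Going by these compounds, how a chloro, methyl or carboxamide group on this same aromatic carbon would read in this assay also remains open.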